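This account rests on a few compounds, and the source may have more. Where it says the series, first, only, none or still open, it means among the compounds named here.

Two compounds with a shared core were measured in a functional assay on the whole organism with Mus musculus as the target; a lower number here means a smaller maximal response, a higher number a larger maximal response. Compound 1 `C=CCn1c(=S)n(C2OC(COCc3ccccc3)[C@H]3OC(C)(C)O[C@@H]23)c2nc(N)nc(O)c21` gives 0% in this assay, the lower of the two numbers recorded. Compound 2 `COc1ccc(Cn2c(=O)n(C3OC(CO)[C@@H](O)[C@H]3O)c3nc(N)nc(O)c32)cc1` gives 14% in this assay, and the two values show a gap that lies beyond the usual scatter; since compound 1 and compound 2 differ in more than one place, nothing is drawn from that gap about any single change.

Compound 3 `C=CCn1c(=S)n(C2OC(COC(C)=O)[C@H]3OC(C)(C)O[C@@H]23)c2nc(N)nc(O)c21` has not yet been measured in this assay. It differs from compound 1 in one place: acetyl in place of benzyl on an oxygen on a saturated carbon. For the measured compounds named here, no measured pair covers this change, so there is no step that would point in either direction, and the expectation rests on compound 1 alone.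

Compound 3 is expected to stay close to compound 1, because compound 1 gives 0% and the replacement of benzyl by acetyl is an untested change; the step from a number 4 percentage points higher from compound 1 to compound 3 (within the scatter) is estimated to be small, within the scatter, if anything slightly upward. Compound 3 is therefore estimated at 4% in this assay, with a range from 0% to 20%.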

Compound 3, largest response reached (reported as maximal response), in percent of the reference or control that the assay uses: 20%
The estimate for compound 3 lay 16 percentage points below the measured number; the measured number falls inside the stated range.
By their numbers in this assay, from the lowest: compound 1; then compounds 2 and 3 (each within the scatter of the next).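

In this assay, for the compounds shown here, the exchange of benzyl for acetyl on an oxygen on a saturated carbon gives a number 20 percentage points higher from compound 1 to compound 3 (beyond the scatter) and is the first change in a single place that can be read here, so the response does depend on what this oxygen carries. The change removes a group of 7 heavy atoms with an aromatic ring and brings in one of 3 heavy atoms with no ring and 1 hydrogen-bond acceptor, and this one step cannot show which of these differences matters. Nothing shown here bears on why the number moves.

A benzoyl group on the same oxygen, which keeps the aromatic ring and adds a carbonyl, and a plain methyl group, which has neither, would help separate those differences. From the compounds shown here alone, it also remains open whether the same exchange would give a similar step on a compound without the allyl group and the thione-bearing core of compound 1, such as the differently substituted compound 2.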